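The source may report more compounds than this note shows. Statements on the series, on what has been measured and on what is new or still open speak of the compounds shown alone.

Compound 1 `Cc1ccc(S(=O)(=O)Nc2ccc3c(c2)C(=O)N(CCCCBr)C3=O)cc1`: in an assay on isolated protein for inhibition of lactase/phlorizin hydrolase (Rattus norvegicus), read by colorimetric assay (on this read-out higher numbers stand for weaker inhibition and lower numbers for stronger inhibition), compound 1 gives > 200000 nM, a limit of the assay.
Compound 2 `Cc1ccc(S(=O)(=O)Nc2ccc3c(c2)C(=O)N(Cc2ccccc2)C3=O)cc1`: in this assay compound 2 gives > 200000 nM, likewise a limit.

Compound 2 therefore stands only at a limit, and both values shown sit at the limit of > 200000 nM in this assay, at which 2 of the 2 values shown sit. For the measured compounds named here, the one measured step, a step that the two limits leave unreadable from compound 1 to compound 2, is unreadable. Compound 3 `Cc1ccc(S(=O)(=O)Nc2ccc3c(c2)C(=O)N(Cc2ccc(Cl)c(Cl)c2)C3=O)cc1` differs from compound 2 by 3,4-dichlorophenyl in place of phenyl on a saturated chain carbon bound to an amide-type nitrogen in a ring. No readable step bears on this change, so no step beyond the scatter is expected, a step that the limit leaves unreadable from compound 2 to compound 3. Compound 3 is expected at 300000 nM, between 100000 nM and 1000000 nM, most likely again reported only as a limit.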

Compound 3, half-maximal inhibitory concentration: 101000 nM
For compound 3 the middle estimate is 3.0-fold (0.47 log units) above the measured one; the range from low to high includes it.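

In this assay compound 3 is the only one of the three shown to give a number rather than a limit, so this place on the saturated chain carbon now has a readable value: 101000 nM. The change to 3,4-dichlorophenyl gives an at least 1.9-fold lower number from compound 2 to compound 3 (0.29 log units; that floor lies within the scatter), and the change from 3-bromopropyl gives an at least 1.9-fold lower number from compound 1 to compound 3 (0.29 log units; that floor lies within the scatter), so neither floor establishes a gain beyond the scatter. The step between the two other compounds cannot be read, and they offer only a limit to compare with: the limit of > 200000 nM in this assay, at which 2 of the 3 values shown sit.

Going by these compounds, whether a single chlorine, a methoxy group, an amine or a carboxylic acid in this place would move the number further stays open.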